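The source may report more compounds than this note shows. Statements on the series, on what has been measured and on what is new or still open speak of the compounds shown alone.

Measured compounds:
compound 1 `Cc1nc(N2CCCCC2)c2nnn(-c3ccc(C(C)C)cc3Br)c2n1` — 46 nM
compound 2 `COCC(C)(C)Nc1nc(C)nc2c1nnn2-c1ccc(C(C)C)cc1Br` — 195 nM
compound 3 `COCCNc1nc(C)nc2c1nnn2-c1ccc(C(C)C)cc1Br` — 242 nM

These three share a core and differ only in the group attached to one of its aromatic carbons. In an in vitro assay on 293-EBNA cells for binding affinity to corticotropin-releasing factor receptor 1 (Homo sapiens) (a higher number here means a weaker inhibitor, a lower number a stronger inhibitor), compound 1, which carries a piperidin-1-yl ring at that position, gives 46 nM. Opening the ring into an amine carrying an alkyl chain with a methoxy group costs affinity: a 4.2-fold higher number from compound 1 to compound 2 (0.63 log units; beyond the scatter) and a 5.3-fold higher number from compound 1 to compound 3 (0.72 log units; beyond the scatter). Between the two open-chain amines the difference is small: a 1.2-fold higher number from compound 2 to compound 3 (0.09 log units; within the scatter). Compound 3 thus has the highest number of the three, but against compound 2 this is within the scatter, so the two cannot be ranked.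

Compound 4 `CCC(CO)Nc1nc(C)nc2c1nnn2-c1ccc(C(C)C)cc1Br` has not yet been measured. It differs from compound 3 in one place: 1-(hydroxymethyl)propyl in place of 2-methoxyethyl on a nitrogen on an aromatic ring. Going by the values given here, the only measured step that bears on this kind of change is the one from compound 2 to compound 3, where swapping one methoxy-bearing chain for another moved the number within the scatter. Among the compounds with values here, no measured step shows what trading the methoxy group for a hydroxyl does. The branched chain of compound 4 resembles that of compound 2 more than that of compound 3, so if anything a small move towards lower numbers is expected, a 1.2-fold lower number from compound 3 to compound 4 (0.08 log units; within the scatter), but nothing beyond the scatter. Compound 4 is therefore estimated at 200 nM in this assay, with a likely range from 80 nM to 500 nM.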

Compound 4, inhibition constant: 25.3 nM
Beside the measured number, compound 4's estimate is 7.9-fold (0.90 log units) above it; the whole stated range lies above it.
By their numbers in this assay, from the lowest: compounds 4 and 1 (each within the scatter of the next); then compounds 2 and 3 (each within the scatter of the next).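

In this assay, going by these compounds alone, this position proves far more sensitive to the exact open chain than the earlier compounds suggested: 1-(hydroxymethyl)propyl gives a 9.6-fold lower number from compound 3 to compound 4 (0.98 log units; beyond the scatter) and a 7.7-fold lower number from compound 2 to compound 4 (0.89 log units; beyond the scatter), whereas the two methoxy-bearing chains could not be told apart. Opening the ring therefore does not have to cost affinity, since a 1.8-fold lower number from compound 1 to compound 4 (0.26 log units; within the scatter) leaves the hydroxyl-bearing amine and the piperidin-1-yl ring unranked, although compound 2 and compound 3 still go against any general claim about open chains. Nothing available explains why the hydroxyl-bearing chain behaves so differently from the methoxy-bearing ones.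

The change from 2-methoxyethyl to 1-(hydroxymethyl)propyl alters several things at once: the oxygen now carries a hydrogen-bond donor, and the chain has a different shape and one more heavy atom, so the compounds shown cannot say which of these matters. Placing a 2-hydroxyethyl group or a 1-(methoxymethyl)propyl group on the same nitrogen would separate the hydroxyl from the branching, each differing from compound 3 or compound 4 in a single feature.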